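This account rests on a few compounds, and the source may have more. Where it says the series, first, only, none or still open, it means among the compounds named here.

Of the compounds shown here, two of this study have so far been measured in an ADME assay on HEp-2 cells (Homo sapiens) for cytotoxicity, with a stated time of 4 days; a lower number here means that less compound is tolerated, a higher number that more compound is tolerated. Compound 1 `CS(=O)(=O)CCn1c(Cn2cc(S(C)(=O)=O)c3ccccc32)nc2cc(Cl)ccc21` gives > 100000 nM, which is a limit of the assay rather than a number. Compound 2 `CNS(=O)(=O)c1cn(Cc2nc3cc(Cl)ccc3n2CCCS(C)(=O)=O)c2ccccc12` gives > 100000 nM, likewise a limit of the assay and not a number. Going by the values given here, compound 2 therefore stands exactly where every recorded value stands: both results sit at the limit of > 100000 nM in this assay, at which 2 of the 2 values shown sit, so no step between two measured numbers exists here, and nothing in the data sets one of these two compounds apart from the other.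

Compound 3 `CCS(=O)(=O)c1cn(Cc2nc3cc(Cl)ccc3n2CCCS(C)(=O)=O)c2ccccc12` is the next compound to be measured in this assay. It differs from compound 2 in a single place: ethyl in place of methylamino on a sulfonyl sulfur, or, read one bond further out, methylsulfamoyl to ethylsulfonyl. Since compound 2 sits at the limit of > 100000 nM in this assay, at which 2 of the 2 values shown sit, the step of a number no higher from compound 2 to compound 3 (the limit leaves the size open) is expected to be none beyond the scatter. Compound 3 is accordingly expected to give 100000 nM, with a range from 30000 nM to 300000 nM, most probably again reported only as a limit.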

Compound 3, half-maximal cytotoxic concentration: > 100000 nM
Compound 3: only a limit was reported; the forecaster's own chance of this, stated with the estimate: 80%; the middle value lies on the limit itself.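

In this assay compound 3 gives > 100000 nM and this is a limit of the assay, not a number. Going by these compounds alone, compound 2 also stands at a limit, so no step from it to compound 3 can be read. The compounds shown leave open at what concentration any of them harms these cells, and whether swapping methylamino for ethyl on the sulfonyl sulfur changes that concentration.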